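Methoxy for Fluoro on the Aryl Ring of Compound 1

A few compounds are considered here, and "the series" means these few. Any claim that something is new, unique, unknown or untested is made for them only; others in the source may bear on it.

Compound 1 `O=C(Nc1nc2ccccc2s1)c1cn(-c2ccccc2)nc1-c1ccc(F)cc1` gives 10700 nM in a functional assay on U-87MG ATCC cells for cytotoxicity against U-87 MG (Homo sapiens), read by MTT assay, with a stated time of 72 h (on this read-out higher numbers stand for weaker inhibition and lower numbers for stronger inhibition), the second highest of the three numbers recorded, though all three lie within the scatter of one another. Compound 2 `O=C(Nc1nc2ccc(F)cc2s1)c1cn(-c2ccccc2)nc1-c1ccc(F)cc1` gives 12500 nM and compound 3 `O=C(Nc1nc2ccc(Cl)cc2s1)c1cn(-c2ccccc2)nc1-c1ccc(F)cc1` gives 6770 nM. The steps of a 1.2-fold higher number from compound 1 to compound 2 (0.07 log units; within the scatter) and a 1.6-fold lower number from compound 1 to compound 3 (0.20 log units; within the scatter) both replace a hydrogen on the shared core, and a 1.8-fold lower number from compound 2 to compound 3 (0.27 log units; within the scatter) is likewise within the scatter. Compound 4 `COc1ccc(-c2nn(-c3ccccc3)cc2C(=O)Nc2nc3ccccc3s2)cc1` differs from compound 1 by methoxy in place of fluoro on an aromatic carbon. Among the compounds with values here, no measured step touches this ring, so the three steps bear on it only in showing that small peripheral changes left this assay within the scatter. On that basis compound 4 is expected to stand close to compound 1, with a 1.1-fold lower number from compound 1 to compound 4 (0.03 log units; within the scatter) as the estimated step. The estimate for compound 4 is 10000 nM, in the range 3500 nM to 30000 nM.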

Compound 4, half-maximal inhibitory concentration: 11500 nM
Beside the measured number, compound 4's estimate is 1.2-fold (0.06 log units) below it; low and high end bracket the measured number.
By their numbers in this assay, from the lowest: compounds 3, 1, 4 and 2 (each within the scatter of the next).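

Within the data shown here, the exchange of 4-fluorophenyl for 4-methoxyphenyl gives a 1.1-fold higher number from compound 1 to compound 4 (0.03 log units; within the scatter) in this assay, the first reading at this ring, on an aromatic carbon para to a large group. Here methoxy brings one hydrogen-bond acceptor where fluoro has none, and the values of the two compounds remain within the scatter. No available evidence bears on this result.

On these data alone, whether an amine or a carboxylic acid at this place would move the number beyond the scatter remains open. So does the effect of a longer chain, such as butoxy.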